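The compounds below may be only part of what the source reports. "The series", "measured", "known", "first", "only" and "open" are said of these compounds alone.

Compound 1 `O=C(O)c1cccc(-c2ccc(/C=C3\S/C(=N\c4ccc(Cl)cc4)N(c4ccc(Cl)cc4)C3=O)s2)c1` and compound 2 `O=C(O)c1cccc(-c2ccc(/C=C3\S/C(=N\c4ccc(F)cc4)N(c4ccc(F)cc4)C3=O)o2)c1` share the same core and differ elsewhere. In an ADME assay on Vero cells (Chlorocebus sabaeus) for cytotoxicity (on this read-out higher numbers stand for lower toxicity in this test and lower numbers for higher toxicity in this test), compound 1 gives > 200000 nM, which is a limit of the assay rather than a number. In this assay compound 2 likewise gives > 200000 nM, also a limit. Compound 1 thus stands at the limit of > 200000 nM in this assay, at which 2 of the 2 values shown sit, and on these numbers it cannot be ranked against compound 2. Compound 3 `O=C(O)c1cccc(-c2ccc(/C=C3\S/C(=N\c4ccccc4)N(c4ccc(Cl)cc4)C3=O)s2)c1` differs from compound 1 by hydrogen in place of chloro on an aromatic carbon. No step between two measured compounds covers this change, so no size can be drawn from the numbers shown; both measured compounds sit at the limit, and nothing points to a shift beyond the scatter in either direction. Compound 3 is therefore expected to stay at or near the limit, with an estimated step that the limit leaves unreadable from compound 1 to compound 3. The estimate for compound 3 in this assay is 250000 nM, within 100000 nM to 600000 nM, and it is most likely reported again as a limit only.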

Compound 3, half-maximal cytotoxic concentration: > 200000 nM
Compound 3: a limit, no number; the forecaster's own chance of this, stated with the estimate: 85%; the middle value does not contradict the limit.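

In this assay compound 3 gives > 200000 nM, a limit and not a number, so no step from compound 1 to compound 3 can be read: the limit of > 200000 nM in this assay, at which 3 of the 3 values shown sit.

The compounds shown leave open whether 4-chlorophenyl to phenyl shifts cytotoxicity at all, and how any compound here would rank in this assay.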